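Stripping the Halogens from the Amide Aryl Ring

The source may report more compounds than this note shows. Statements on the series, on what has been measured and on what is new or still open speak of the compounds shown alone.

Measured compounds:
- compound 1, `COc1cc(-c2nn(-c3cccc(NC(=O)Nc4ccc(Cl)c(Cl)c4)c3)cc2-c2ccncc2)ccc1Cl`: 570 nM
- compound 2, `COc1cc(-c2nn(-c3cccc(NC(=O)c4ccc(Cl)c(C(F)(F)F)c4)c3)cc2-c2ccncc2)ccc1Cl`: 3690 nM

In a functional assay on MDA-MB-468 cells (Homo sapiens) for inhibition, read by sulforhodamine B assay, with a stated time of 48 h (a higher number here means a weaker inhibitor, a lower number a stronger inhibitor), compound 1 gives 570 nM and compound 2 gives 3690 nM. Among the measured compounds shown here, the single measured step, a 6.5-fold higher number from compound 1 to compound 2 (0.81 log units; beyond the scatter), is the whole of the record, and it places compound 2 as the weaker of the two compounds, with compound 1 the nearest point. Compound 3, `COc1cc(-c2nn(-c3cccc(NC(=O)c4ccccc4)c3)cc2-c2ccncc2)ccc1Cl`, keeps the amide linkage of compound 2 and alters only the ring attached to the carbonyl: phenyl in place of 4-chloro-3-(trifluoromethyl)phenyl on a carbonyl carbon. For the measured compounds named here, no measured step changes a substituent on this ring; the one step on record concerns the link between the carbonyl and the ring, not the ring itself, so it offers no direct guide to the size of this change. The expectation therefore rests on compound 2 alone, which in this assay already gives 3690 nM, and the estimate leans toward a further weakening rather than a recovery, with a wide range. For compound 3 the expected value is 8000 nM, spanning 2000 nM to 30000 nM, which corresponds to an expected step of a 2.2-fold higher number from compound 2 to compound 3 (0.34 log units; beyond the scatter).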

Compound 3, half-maximal inhibitory concentration: 350 nM
The estimate for compound 3 lay 23-fold (1.36 log units) above the measured number; the whole stated range lies above it.
By their numbers in this assay, from the lowest: compounds 3 and 1 (each within the scatter of the next); then compound 2.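

In this assay, phenyl in place of 4-chloro-3-(trifluoromethyl)phenyl on a carbonyl carbon gives a large gain (an 11-fold lower number from compound 2 to compound 3 (1.02 log units; beyond the scatter)), so the amide series does not need the chlorine and trifluoromethyl on this ring, and in compound 2 the pair goes with far weaker inhibition than the bare ring does. The same amide linkage that looked poor in the earlier comparison is therefore not poor in itself: set against the (3,4-dichlorophenyl)amino group on the carbonyl carbon, plain phenyl lands level with it (a 1.6-fold lower number from compound 1 to compound 3 (0.21 log units; within the scatter)), which leaves compound 1 and compound 3 indistinguishable in this assay. Nothing available here explains why removing these groups helps.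

The compounds shown leave open which of the two substituents accounts for the loss, as no ring among them carries the chlorine or the trifluoromethyl alone. Also open, from the compounds shown here alone, is whether a methoxy group or an amine on this phenyl ring would improve on compound 3 or weaken it, and how an unsubstituted phenylamino group on the carbonyl carbon would compare.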